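Thiazole for pyridine on the amide carbonyl

A few compounds are considered here, and "the series" means these few. Any claim that something is new, unique, unknown or untested is made for them only; others in the source may bear on it.

Within the data shown here, compound 2 `O=C(Nc1ccc(Cl)c(-c2nnc3c(Cl)cccn23)c1)c1ccccn1` stands highest of the two numbers measured so far in a functional assay on MDA-MB-231 cells (Homo sapiens) for antiproliferative activity, read by MTT assay, with stated times of 72 h and 4 h (a lower number here means a stronger inhibitor, a higher number a weaker inhibitor), where compound 2 gives 92000 nM. Its nearest neighbour is compound 1 `O=C(Nc1ccc(Cl)c(-c2nnc3c(Cl)cccn23)c1)c1ccc(F)cc1Cl`, which in this assay gives 75000 nM, and the step of a 1.2-fold higher number from compound 1 to compound 2 (0.09 log units; within the scatter) lies within the scatter. Compound 3 `Cc1nc(C(=O)Nc2ccc(Cl)c(-c3nnc4c(Cl)cccn34)c2)cs1` differs from compound 2 by 2-methyl-1,3-thiazol-4-yl in place of pyridin-2-yl on a carbonyl carbon. Among the measured compounds shown here, the only measured step that bears on this change is the exchange of one aryl group for another on the same carbonyl carbon, a 1.2-fold higher number from compound 1 to compound 2 (0.09 log units; within the scatter), which was too small to count as a change. On that basis the step to compound 3 is expected to be small as well, with no direction beyond the scatter. Compound 3 is therefore estimated at 85000 nM in this assay, within 30000 nM to 250000 nM. The expected step is thus a 1.1-fold lower number from compound 2 to compound 3 (0.03 log units; within the scatter).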

Compound 3, half-maximal inhibitory concentration: > 100000 nM
Compound 3: no number, only a limit; the forecaster's own chance of this, stated with the estimate: 25%; middle value at least 1.1-fold (0.07 log units) from the limit.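

In this assay compound 3 gives > 100000 nM, which is a limit of the assay and not a number. The steps read an at least 1.0-fold higher number from compound 2 to compound 3 (0.03 log units; that floor lies within the scatter) and an at least 1.3-fold higher number from compound 1 to compound 3 (0.12 log units; that floor lies within the scatter), so a five-membered aromatic ring with sulfur on this carbonyl carbon brings no lower number than the two six-membered aromatic rings did. All three aryl groups thus leave the series weak in this assay, but how far the thiazole lies from the other two cannot be told: the limit of > 100000 nM in this assay, at which 1 of the 3 values shown sits.

Going by these compounds, it remains open whether anything on this carbonyl carbon can lower the number, for instance a piperidine, a primary amine or a carboxylic acid carried on a short alkyl chain. On these data alone, it also remains open whether changes elsewhere on the shared core would matter more than this position.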